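Trimming the Aryl Group From a Retinoid Enyne Acid

A few compounds are considered here, and "the series" means these few. Any claim that something is new, unique, unknown or untested is made for them only; others in the source may bear on it.

Measured so far:
Compound 1 `CC1(C)CCC(C)(C)c2cc(C/C=C/c3ccc(C(=O)O)cc3)ccc21` — 5 nM
Compound 2 `CCc1ccc(C2=C(/C=C/C#Cc3ccc(C(=O)O)cc3)C(C)(C)CCC2)cc1` — 4 nM

Of the compounds shown here, two have been measured in an assay on isolated protein for binding affinity to retinoic acid receptor beta (Homo sapiens), read by radioligand binding; on this read-out lower numbers stand for tighter binding and higher numbers for weaker binding. Compound 1 `CC1(C)CCC(C)(C)c2cc(C/C=C/c3ccc(C(=O)O)cc3)ccc21` gives 5 nM in this assay. Going by the values given here, compound 2 `CCc1ccc(C2=C(/C=C/C#Cc3ccc(C(=O)O)cc3)C(C)(C)CCC2)cc1` gives 4 nM in this assay, a number that lies within the usual scatter of the one for compound 1, so the two cannot be told apart.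

Compound 3 `CC1=C(/C=C/C#Cc2ccc(C(=O)O)cc2)C(C)(C)CCC1` has not yet been measured. It differs from compound 2 by methyl in place of 4-ethylphenyl on a double-bonded ring carbon, a methyl in place of 4-ethylphenyl on a double-bonded ring carbon. Among the compounds with values here, no pair of measured compounds covers a change of this kind, so nothing measured here sets its size. Compound 3 is expected to show a step of a 30-fold higher number from compound 2 to compound 3 (1.48 log units; beyond the scatter) in this assay, toward weaker binding and clearly beyond the scatter. Compound 3 is estimated at 120 nM in this assay, with a range from 15 nM to 1000 nM.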

Compound 3, dissociation constant: 20 nM
The estimate for compound 3 lay 6.0-fold (0.78 log units) above the measured number; low and high end bracket the measured number.
By their numbers in this assay, from the lowest: compounds 2 and 1 (each within the scatter of the next); then compound 3.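

In this assay, going by these compounds alone, replacing the 4-ethylphenyl on the double-bonded ring carbon with methyl gives a 5.0-fold higher number from compound 2 to compound 3 (0.70 log units; beyond the scatter), the first change in this set that lies beyond the scatter. This ring carbon is therefore a place where the group matters to the read-out, with weaker binding for methyl than for 4-ethylphenyl. The step is modest, though, so binding does not depend on keeping the aromatic ring of the 4-ethylphenyl, and nothing at hand accounts for the size of this step.

As far as these compounds go, whether a plain phenyl, an ethyl or a 4-methoxyphenyl on this ring carbon would fall between compound 3 and compound 2 remains open. So does whether a hydroxyl or an amine at the end of a short chain there would be tolerated, and whether the same step would appear on the core of compound 1.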